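Phosphate Ester in Place of Dimethylaminomethyl: Expecting Compound 3

This account rests on a few compounds, and the source may have more. Where it says the series, first, only, none or still open, it means among the compounds named here.

Compound 1, `Cc1ccccc1NC(=O)Nc1ccc(-n2cc(CCCN(C)C)nn2)cc1`, gives 2900 nM in an assay on isolated protein for inhibition of ATP-dependent RNA helicase DDX3X (Homo sapiens), read by FRET, with stated times of 30 s and 40 min; on this read-out higher numbers stand for weaker inhibition and lower numbers for stronger inhibition.
Compound 2, `CCCCc1cn(-c2ccc(NC(=O)Nc3cc(O[C@H]4O[C@@H](CO)[C@H](O)[C@@H]4O)ccc3C)cc2)nn1`, gives "not active" (no number reported) in this assay.

Among the measured compounds shown here, compound 1 is the only compound with a number in this assay; compound 2 carries a different core decoration and was reported without one, so it offers no measured step. Compound 3, `CCOP(=O)(OCC)OCCc1cn(-c2ccc(NC(=O)Nc3ccccc3C)cc2)nn1`, keeps the urea and core of compound 1 and differs from it by a group of 9 heavy atoms (4 carbon, 4 oxygen, 1 phosphorus; no ring) in place of a group of 4 heavy atoms (3 carbon, 1 nitrogen; no ring), on a saturated chain carbon, two bonds along the chain from an aromatic carbon. For the measured compounds named here, no pair of measured compounds shows what this kind of change does, so the expectation rests on compound 1 alone. The step from compound 1 to compound 3 is expected to be small, at most a modest move toward weaker inhibition, and it may not rise beyond the usual scatter: a 1.7-fold higher number from compound 1 to compound 3 (0.24 log units; within the scatter). Compound 3 is therefore estimated at 5000 nM in this assay, within a range from 1500 nM to 20000 nM.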

Compound 3, half-maximal inhibitory concentration: 890 nM
For compound 3 the middle estimate is 5.6-fold (0.75 log units) above the measured one, outside the stated range (below it).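

In this assay the saturated chain carbon, two bonds along the chain from an aromatic carbon, proves open to substantial change: with the urea and the shared core held fixed, replacing (dimethylamino)methyl with the larger, phosphorus-bearing group gives a 3.3-fold lower number from compound 1 to compound 3 (0.51 log units; beyond the scatter) and thus a modest gain that lies beyond the usual scatter. This single pair shows that the nitrogen of the (dimethylamino)methyl group is not required for a measurable number in this series, and that a group of 9 heavy atoms can stand in its place. Nothing measured on these compounds speaks to the reason for this step.

On these data alone, whether a carboxylic acid, a primary amine or a longer chain on the same carbon would move the number in the same direction remains open. As far as these compounds go, it is also open whether the step would hold if the methyl-bearing ring beyond the urea were changed.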